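The source may hold more compounds than are shown below. What is called first, only, known or untested is meant among the compounds shown, and "the series" means these compounds.

Measured compounds:
- compound 1 `COc1cccc(CNCCCNc2ccnc3cc(Cc4ccc(C#N)cc4)ccc23)c1O`: 7150 nM
- compound 2 `c1coc(CNCCCNc2ccnc3cc(-c4cccc5ccccc45)ccc23)c1`: 5600 nM

Both compounds were read in an ADME assay on HepG2 cells (Homo sapiens) for cytotoxicity, read by luminescence, CellTiter-Glo and ATP content, with a stated time of 72 h; on this read-out higher numbers stand for an effect only at larger amounts of compound and lower numbers for an effect already at smaller amounts. In this assay compound 1 gives 7150 nM, and compound 2 gives 5600 nM. Within the data shown here, compound 2 and compound 1 lie within the usual scatter of one another on this read-out, so no difference between them is established, and with only two compounds measured there is no pattern to lean on.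

Compound 3 `COc1cccc(CNCCCNc2ccnc3cc(-c4cccc5ccccc45)ccc23)c1O` has not yet been measured in this assay. It differs from compound 2 in one place: 2-hydroxy-3-methoxyphenyl in place of furan-2-yl on a saturated chain carbon bound to an amine nitrogen. The group that enters is the same one that compound 1 carries at this position, and compound 1 shows a number close to compound 2 in this assay, so the change offers no ground to expect a move beyond the scatter. Compound 3 is therefore expected to give 6500 nM in this assay, with a plausible range from 3000 nM to 14000 nM. The step that this estimate implies, a 1.2-fold higher number from compound 2 to compound 3 (0.06 log units; within the scatter), is expected to stay within the scatter in this assay.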

Compound 3, half-maximal effective concentration: 2520 nM
Compound 3: the middle estimate sits 2.6-fold (0.41 log units) above what was measured, outside the stated range (below it).
By their numbers in this assay, from the lowest: compound 3; then compounds 2 and 1 (each within the scatter of the next).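

Among these compounds, with naphthalen-1-yl held in place on the aromatic carbon, 2-hydroxy-3-methoxyphenyl in place of furan-2-yl on a saturated chain carbon bound to an amine nitrogen gives a 2.2-fold lower number from compound 2 to compound 3 (0.35 log units; beyond the scatter) in this assay, the first step at this position that can be read from a single change. With 2-hydroxy-3-methoxyphenyl held in place instead, naphthalen-1-yl in place of 4-cyanobenzyl on an aromatic carbon gives a 2.8-fold lower number from compound 1 to compound 3 (0.45 log units; beyond the scatter). Compound 1 and compound 2 differ in both places and lie within the scatter of each other, so their closeness had hidden two modest steps, and compound 3, which carries both of the groups named in these steps, has the lowest number of the three.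

Nothing available explains either step or shows what lies behind this cytotoxicity read-out. The compounds shown leave open whether the hydroxyl or the methoxy of the 2-hydroxy-3-methoxyphenyl group matters more, which 2-hydroxyphenyl, 3-methoxyphenyl or plain phenyl at the same place could separate, and whether the step from furan-2-yl would also appear with 4-cyanobenzyl on the aromatic carbon.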